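Swapping Methoxymethyl for 1-Hydroxyethyl on the Side Chain

The source may hold more compounds than are shown below. What is called first, only, known or untested is meant among the compounds shown, and "the series" means these compounds.

In a functional assay on DU-145 cells (Homo sapiens) for cytotoxicity, read by MTT assay (a higher number here means a weaker inhibitor, a lower number a stronger inhibitor), compound 1 `CC(=O)OCCC(=O)O[C@H](CC=C(C)C)C1=CC(=O)c2c(O)ccc(O)c2C1=O` gives 15700 nM as its result. Compound 2 `COCCO[C@H](CC=C(C)C)C1=CC(=O)c2c(O)ccc(O)c2C1=O` gives 43200 nM and so holds the higher, weaker number of the two. Compound 3 `CC(C)=CC[C@@H](OCC(C)O)C1=CC(=O)c2c(O)ccc(O)c2C1=O` has not been measured yet. It has 1-hydroxyethyl in place of methoxymethyl on a saturated chain carbon bound to an oxygen on a saturated carbon and shares the same atoms as compound 2, joined differently. For the measured compounds named here, the only measured step is a 2.8-fold higher number from compound 1 to compound 2 (0.44 log units; beyond the scatter) where 2-methoxyethyl replaces (2-acetoxyethyl)carbonyl. That is a different swap, so it offers only a rough guide to size, and none to direction. A small shift is therefore expected, with the estimated step being a 1.4-fold lower number from compound 2 to compound 3 (0.16 log units; within the scatter) in this assay at most. Compound 3 is estimated at 30000 nM with an expected range from 12000 nM to 75000 nM for this measurement.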

Compound 3, half-maximal inhibitory concentration: 16100 nM
Compound 3: middle estimate off by 1.9-fold (0.27 log units), on the high side; measured number inside the range.
By their numbers in this assay, from the lowest: compounds 1 and 3 (each within the scatter of the next); then compound 2.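

In this assay, the side chain responds to how its atoms are arranged, not only to which atoms it holds: 2-hydroxypropyl in place of 2-methoxyethyl gives a 2.7-fold lower number from compound 2 to compound 3 (0.43 log units; beyond the scatter) even though the two compounds have the same atoms. Replacing (2-acetoxyethyl)carbonyl with 2-hydroxypropyl gives a 1.0-fold higher number from compound 1 to compound 3 (0.01 log units; within the scatter) and so does not separate these two groups in this assay. The entering 1-hydroxyethyl carries a hydrogen-bond donor that methoxymethyl lacks, but no measurement shown ties the step to that donor or to any other cause.

As far as these compounds go, it remains open whether the hydroxyl or the branched shape of the 2-hydroxypropyl chain matters more, which a comparison with an unbranched 2-hydroxyethyl chain could help to separate. It is also unknown how an amine, such as 2-aminopropyl, would behave on this oxygen.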